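Amide-nitrogen swap from compound 3 to compound 4

The compounds below may be only part of what the source reports. "The series", "measured", "known", "first", "only" and "open" are said of these compounds alone.

In a functional assay on HepG2 cells (Homo sapiens) for antiproliferative activity, read by MTT assay, with a stated time of 48 h (a higher number here means a weaker inhibitor, a lower number a stronger inhibitor), the measured compounds are these:
- compound 1 `CCn1c(C(=O)NCCN)ccc1C(CC)(CC)c1ccc(OCCC(O)(CC)CC)c(C)c1` gives 1590 nM here
- compound 2 `C#CC(C)OC(=O)c1ccc(C(CC)(CC)c2ccc(OCCC(O)(CC)CC)c(C)c2)n1CC` gives > 50000 nM as a limit of the assay
- compound 3 `CCC(C)C(NC(=O)c1ccc(C(CC)(CC)c2ccc(OCCC(O)(CC)CC)c(C)c2)n1CC)C(=O)O` gives 2620 nM here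

Among the measured compounds shown here, compound 3 has compound 1 as its only numeric neighbour, and the two values lie within the scatter of each other. Going to compound 4 `CCn1c(C(=O)NC(CC(=O)O)C(=O)OC)ccc1C(CC)(CC)c1ccc(OCCC(O)(CC)CC)c(C)c1` the change is a group of 9 heavy atoms (5 carbon, 4 oxygen; no ring) in place of a group of 8 heavy atoms (6 carbon, 2 oxygen; no ring), on an amide-type nitrogen and the nitrogen stays amide-type. The closest measured step is a 1.6-fold higher number from compound 1 to compound 3 (0.22 log units; within the scatter) on that same kind of nitrogen. The large steps of an at least 31-fold higher number from compound 1 to compound 2 (1.49 log units; beyond the scatter) and an at least 19-fold lower number from compound 2 to compound 3 (1.28 log units; beyond the scatter) both turn on the (1-methylprop-2-yn-1-yl)oxy on a carbonyl carbon, which compound 4 does not carry. In this assay no step beyond the scatter is therefore expected, estimated as a 1.1-fold higher number from compound 3 to compound 4 (0.06 log units; within the scatter) for this change. The estimate for compound 4 is 3000 nM with an expected range from 1000 nM to 10000 nM in this read-out.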

Compound 4, half-maximal inhibitory concentration: 10700 nM
Compound 4: middle estimate off by 3.6-fold (0.55 log units), on the low side, and the stated range ends below it.
By their numbers in this assay, from the lowest: compounds 1 and 3 (each within the scatter of the next); then compound 4. At a limit, above all of these: compound 2.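

In this assay, the amide-type nitrogen does respond to its substituent: the group entering in compound 4, in place of 1-carboxy-2-methylbutyl, gives a 4.1-fold higher number from compound 3 to compound 4 (0.61 log units; beyond the scatter), and in place of 2-aminoethyl it gives a 6.7-fold higher number from compound 1 to compound 4 (0.83 log units; beyond the scatter). Both steps lie beyond the scatter, unlike a 1.6-fold higher number from compound 1 to compound 3 (0.22 log units; within the scatter). Compound 2 stands at a limit of the assay, so an at least 4.6-fold lower number from compound 2 to compound 4 (0.66 log units; beyond the scatter) is only a bound: the limit of > 50000 nM in this assay, at which 1 of the 4 values shown sits.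

Which part of the entering group carries the change stays open. A primary amide in place of its methyl ester, or a longer amine chain on this nitrogen, would test that.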